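Pyridin-2-yl in Place of a Trifluoromethylphenyl Group

The compounds below may be only part of what the source reports. "The series", "measured", "known", "first", "only" and "open" are said of these compounds alone.

Measured compounds:
Compound 1, `Cc1ccc(N2CCN(Cc3csc(N)c3C(=O)c3ccc(Cl)cc3)CC2)cc1`, gives 1 nM in an assay on CHO cells for displacement of a labelled ligand from adenosine receptor A1 (Homo sapiens); on this read-out lower numbers stand for tighter binding and higher numbers for weaker binding.
Compound 2, `N#Cc1ccc(N2CCN(Cc3csc(N)c3C(=O)c3ccc(Cl)cc3)CC2)cc1`, gives 1.1 nM in this assay.
Compound 3, `Nc1scc(CN2CCN(c3ccc(C(F)(F)F)cc3)CC2)c1C(=O)c1ccc(Cl)cc1`, gives 1 nM in this assay.

Compound 3 sits level with compound 1, and these two together show the lowest numbers of the three. The steps among them are small: a 1.1-fold higher number from compound 1 to compound 2 (0.04 log units; within the scatter), no change at the digits printed from compound 1 to compound 3 (within the scatter) and a 1.1-fold lower number from compound 2 to compound 3 (0.04 log units; within the scatter) all lie within the scatter, so a cyano, a methyl or a trifluoromethyl on that aromatic carbon made no difference that can be read.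

Compound 4, `Nc1scc(CN2CCN(c3ccccn3)CC2)c1C(=O)c1ccc(Cl)cc1`, differs from compound 3 as follows: pyridin-2-yl in place of 4-(trifluoromethyl)phenyl on an amine nitrogen in a ring. For the measured compounds named here, none of the measured steps touches this kind of change; all three swap one group on the same aromatic carbon, whereas here the whole ring on the amine nitrogen is exchanged. The expectation is therefore loose. A modest weakening is estimated as the step of a 3.0-fold higher number from compound 3 to compound 4 (0.48 log units; beyond the scatter), and the value expected for compound 4 is 3 nM, within a range from 0.8 nM to 15 nM.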

Compound 4, dissociation constant: 1.2 nM
For compound 4 the middle estimate is 2.5-fold (0.40 log units) above the measured one, and the stated range covers the measured number.
By their numbers in this assay, from the lowest: compounds 1, 3, 2 and 4 (each within the scatter of the next).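

Putting pyridin-2-yl on the amine nitrogen, in place of each substituted phenyl ring, gives no difference that can be read in this assay: the steps (a 1.2-fold higher number from compound 3 to compound 4 (0.08 log units; within the scatter)), (a 1.1-fold higher number from compound 2 to compound 4 (0.04 log units; within the scatter)) and (a 1.2-fold higher number from compound 1 to compound 4 (0.08 log units; within the scatter)) all lie within the scatter. For the compounds shown here, the earlier compounds varied only one group on the same aromatic carbon, whereas compound 4 shows that this position also accepts a change of the whole ring, to one with fewer heavy atoms, a ring nitrogen and a hydrogen-bond acceptor. Nothing measured here bears on why the numbers stay level.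

On these data alone, all four compounds keep an aromatic ring on this amine nitrogen, so it remains open how a cyclohexyl ring or a short alkyl chain there would read. Pyridin-3-yl and pyridin-4-yl also remain open.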